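One double bond turned in a long-chain aldehyde

The compounds below may be only part of what the source reports. "The series", "measured", "known", "first", "only" and "open" are said of these compounds alone.

Within the data shown here, compound 1 `COCCCCCCCCCCCCCCC/C=C1/CC(CO)(COC(=O)C(C)(C)C)OC1=O` gives 0.178 ug/mL in a functional assay on COLO 205 cells (Homo sapiens) for antiproliferative activity (on this read-out lower numbers stand for stronger inhibition of growth and higher numbers for weaker inhibition of growth), and provides the only exact number so far. Compound 2 `CC(C)(C)C(=O)OCC1(CO)C/C(=C\CCCCCCCCCCCCCCC=O)C(=O)O1` gives > 10 ug/mL in this assay and this is a limit of the assay, not an exact number. Compound 3 `CC(C)(C)C(=O)OCC1(CO)C/C(=C/CCCCCCCCCCCCCCC=O)C(=O)O1` is the next to be tested. The structural change from compound 2 is the two compounds have the same atoms and bonds; at least one stereo element is drawn with a configuration in one of them and without one in the other: 1 of 2 stereo elements differ; a double bond is drawn E in compound 2 and Z in compound 3 and so the two compounds have the same atoms and bonds, with a double bond drawn E in compound 2 and Z in compound 3. Among the measured compounds shown here, no measured step shows what this change does in this assay so the expectation rests on compound 2 and its limit of > 10 ug/mL alone. The expected move a step that the limit leaves unreadable from compound 2 to compound 3 is small, with no clear direction and nothing beyond the usual scatter. Compound 3 is estimated at 12 ug/mL with an expected range from 4 ug/mL to 30 ug/mL and the assay may again report only a limit.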

Compound 3, concentration for 50% growth inhibition: 5.14 ug/mL
Beside the measured number, compound 3's estimate is 2.3-fold (0.37 log units) above it; measured number inside the range.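

The double-bond change gives an at least 1.9-fold lower number from compound 2 to compound 3 (0.28 log units; that floor lies within the scatter), so this step has a floor but no exact size. Compound 2 remains the open end of that comparison, and its value is a limit of the assay, not an exact number: the limit of > 10 ug/mL in this assay, at which 1 of the 3 values shown sits. Among these compounds, at the end of the chain, formyl in place of methoxymethyl on a saturated chain carbon gives a 29-fold higher number from compound 1 to compound 3 (1.46 log units; beyond the scatter) in this assay, the first readable step here and a large one.

How firmly the double-bond step can be tied to a defined E and Z pair remains uncertain: the fact that one of compounds 2 and 3 is drawn with a defined configuration and the other without, at the place where they differ. Also open, from the compounds shown here alone, is how a carboxylic acid or an amine at the end of the chain would read in this assay.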